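Swapping chloro for amino in two inactive compounds

The source may report more compounds than this note shows. Statements on the series, on what has been measured and on what is new or still open speak of the compounds shown alone.

Compound 1, `Nc1nn(C(=O)Nc2ccc(Cc3ccccc3)cc2)c2ccccc12`, in a functional assay on NCI-H522 cells (Homo sapiens) for antiproliferative activity, read by sulforhodamine B assay, with a stated time of 48 h (a lower number here means that less compound is tolerated, a higher number that more compound is tolerated), gives only the assay limit > 100000 nM.
Compound 2, `Nc1nn(C(=O)Nc2ccc(Cc3ccccc3)cc2)c2ccc(Cl)cc12`, in this assay likewise gives only the limit > 100000 nM.

Going by the values given here, compound 2 thus stands at a limit rather than at a number, and the one further value shown is a limit as well. The step that the two limits leave unreadable from compound 1 to compound 2 stays unreadable because both ends sit at the limit of > 100000 nM in this assay, at which 2 of the 2 values shown sit. Compound 3, `Nc1ccc2c(c1)c(N)nn2C(=O)Nc1ccc(Cc2ccccc2)cc1`, differs from compound 2 by amino in place of chloro on an aromatic carbon. Among the compounds with values here, no measured step bears on this exchange, so the size of the step from compound 2 to compound 3 cannot be anchored in the data. With both known compounds at the limit, the best expectation is that compound 3 is also tolerated up to that limit. The step expected here is a number no higher from compound 2 to compound 3 (the limit leaves the size open). Compound 3 is therefore estimated at 100000 nM, with a range from 30000 nM to 300000 nM.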

Compound 3, concentration lethal to 50% of the cells: > 100000 nM
Compound 3 ended at the assay's limit (the forecaster's own chance of this, stated with the estimate: 75%); the middle value sits exactly at the limit.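

No step can be read among compound 1, compound 2 and compound 3, because all three stop at the same limit rather than at a number: the limit of > 100000 nM in this assay, at which 3 of the 3 values shown sit.

The compounds shown leave open whether hydrogen, chloro or amino on that aromatic carbon makes any difference in this assay.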